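Aromatic amides at the limit of activity

A few compounds are considered here, and "the series" means these few. Any claim that something is new, unique, unknown or untested is made for them only; others in the source may bear on it.

Values in a functional assay on MCF7 cells (Homo sapiens) for antiproliferative activity, read by MTT assay, with a stated time of 48 h; a higher number here means a weaker inhibitor, a lower number a stronger inhibitor:
- Compound 1 `CCn1c(C(=O)NCCN(C)C)ccc1C(CC)(CC)c1ccc(OCCC(O)(CC)CC)c(C)c1`: 430 nM
- Compound 2 `CCn1c(C(=O)Nc2cccc(C(F)(F)F)c2)ccc1C(CC)(CC)c1ccc(OCCC(O)(CC)CC)c(C)c1`: > 50000 nM, a limit

Compound 2 sits at a limit of this assay, > 50000 nM, as noted in the limit of > 50000 nM in this assay, at which 1 of the 2 values shown sits. Compound 3 `CCOc1ccc(NC(=O)c2ccc(C(CC)(CC)c3ccc(OCCC(O)(CC)CC)c(C)c3)n2CC)cc1` has 4-ethoxyphenyl in place of 3-(trifluoromethyl)phenyl on an amide-type nitrogen. Among the measured compounds shown here, the only measured step at this nitrogen, an at least 110-fold higher number from compound 1 to compound 2 (2.06 log units; beyond the scatter), is large, but it replaced 2-(dimethylamino)ethyl, which compound 3 also lacks. Little recovery is therefore expected in this assay, perhaps a small shift towards a lower number. The expected step, an at least 1.2-fold lower number from compound 2 to compound 3 (0.09 log units; that floor lies within the scatter), is an estimate. The estimate for compound 3 is 40000 nM, with an expected range of 10000 nM to 100000 nM.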

Compound 3, half-maximal inhibitory concentration: > 50000 nM
Compound 3 was reported as a limit; the forecaster's own chance of this, stated with the estimate: 60%; middle value at least 1.2-fold (0.09 log units) from the limit.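

With 4-ethoxyphenyl on the amide-type nitrogen, compound 3 also gives only a limit in this assay, > 50000 nM. Replacing 2-(dimethylamino)ethyl with this second aromatic group gives an at least 110-fold higher number from compound 1 to compound 3 (2.06 log units; beyond the scatter), so the large loss is not confined to 3-(trifluoromethyl)phenyl. The step between the two aromatic amides cannot be read, since both stand at the same limit: the limit of > 50000 nM in this assay, at which 2 of the 3 values shown sit.

Going by these compounds, it remains open which part of 2-(dimethylamino)ethyl carries the activity. A 2-aminoethyl, a 3-(dimethylamino)propyl or a 2-hydroxyethyl group on this nitrogen could help separate the amine from the chain.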